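Adding One Methyl to Compound 3

A few compounds are considered here, and "the series" means these few. Any claim that something is new, unique, unknown or untested is made for them only; others in the source may bear on it.

Measured in a functional assay on MDA-MB-435 cells (Homo sapiens) for antiproliferative activity; on this read-out higher numbers stand for weaker inhibition of growth and lower numbers for stronger inhibition of growth:
- compound 1 `Cc1cccc(-c2cc(O)c3ccc(C)nc3n2)c1`: 32.4 nM
- compound 2 `Oc1cc(-c2ccc3ccccc3c2)nc2ncccc12`: 1780 nM
- compound 3 `Cc1ccnc2nc(-c3cccc4ccccc34)cc(O)c12`: < 10 nM (a limit)

Compound 3 has no exact number in this assay. Its result, < 10 nM, is a limit of the assay. Compound 4 `Cc1cc(C)c2c(O)cc(-c3cccc4ccccc34)nc2n1` is the next compound to consider. It differs from compound 3 as follows: methyl in place of hydrogen on an aromatic carbon. This places methyl in place of hydrogen on an aromatic carbon, next to the ring nitrogen.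

For the measured compounds named here, no measured pair isolates this change, so the expectation rests on indirect evidence. Compound 1 also carries a methyl next to the ring nitrogen and gives 32.4 nM, although it differs from compound 3 in other ways too. The expected change, an at least 1.2-fold higher number from compound 3 to compound 4 (0.07 log units; that floor lies within the scatter), is none beyond the usual scatter. For compound 4 the estimated value is 12 nM, with an expected range from 3 nM to 80 nM.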

Compound 4, concentration for 50% growth inhibition: 191 nM
Compound 4: middle estimate off by 16-fold (1.20 log units), on the low side; the measured number lies above the stated range.
By their numbers in this assay, from the lowest: compound 1; then compound 4; then compound 2. At a limit, below all of these: compound 3.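

In this assay, methyl in place of hydrogen on an aromatic carbon, next to the ring nitrogen, proves to be far from a silent change, giving an at least 19-fold higher number from compound 3 to compound 4 (1.28 log units; beyond the scatter). For the compounds shown here, compound 1 also carries a methyl in this place, but it differs from compound 3 in other ways too, so only this pair isolates the change and shows that this one added carbon is enough for a step beyond the scatter. The value of compound 3 is a limit, so the step fixes only a floor and its full size stays unknown: the limit of < 10 nM in this assay, at which 1 of the 4 values shown sits.

The compounds shown leave open whether any other group in this place, such as an ethyl, a methoxy or an amine, would bring a step of similar size. They also leave open whether methyl would have the same effect here on the core of compound 2.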